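The source may hold more compounds than are shown below. What is called first, only, known or untested is meant among the compounds shown, and "the series" means these compounds.

Three compounds share one core and differ only in the group on a carbon with a double bond to nitrogen. In an assay on CHO-K1 cells for displacement of a labelled ligand from adenosine receptor A1 (Homo sapiens), read by scintillation counting, with a stated time of 60 min (on this read-out higher numbers stand for weaker inhibition and lower numbers for stronger inhibition), compound 1 `N#Cc1ccc(/C=N/Nc2nc(N)c3ncn([C@@H]4O[C@H](CO)[C@@H](O)[C@H]4O)c3n2)cc1` gives 4.1 nM, compound 2 `Nc1nc(N/N=C/c2ccc[nH]2)nc2c1ncn2[C@@H]1O[C@H](CO)[C@@H](O)[C@H]1O` gives 8 nM, and compound 3 `Nc1nc(N/N=C/c2ccc(Br)cn2)nc2c1ncn2[C@@H]1O[C@H](CO)[C@@H](O)[C@H]1O` gives 4.7 nM. Compound 3 lies nearest compound 1, where a 1.1-fold higher number from compound 1 to compound 3 (0.06 log units; within the scatter), and furthest from compound 2, where a 1.7-fold lower number from compound 2 to compound 3 (0.23 log units; within the scatter); these steps, like a 2.0-fold higher number from compound 1 to compound 2 (0.29 log units; within the scatter), stay within the scatter. Compound 4 `CSCC/C=N/Nc1nc(N)c2ncn([C@@H]3O[C@H](CO)[C@@H](O)[C@H]3O)c2n1` brings (2-(methylsulfanyl)ethyl in place of 5-bromopyridin-2-yl on a carbon with a double bond to nitrogen). Going by the values given here, every measured step exchanges one aromatic ring for another; none replaces a ring by a chain, so no step rests directly on this change. The step of a 2.6-fold higher number from compound 3 to compound 4 (0.41 log units; beyond the scatter) is therefore an estimate without a close precedent. Compound 4 is expected near 12 nM, in a range from 3 nM to 50 nM.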

Compound 4, inhibition constant: > 10000 nM
Compound 4 gave a limit, no number (the forecaster's own chance of this, stated with the estimate: 5%); middle value at least 830-fold (2.92 log units) away from the limit.
By their numbers in this assay, from the lowest: compounds 1, 3 and 2 (each within the scatter of the next). At a limit, above all of these: compound 4.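

Compound 4 gives a limit, not a number: the limit of > 10000 nM in this assay, at which 1 of the 4 values shown sits.
Going by these compounds alone, the earlier compounds showed only that three different aromatic rings on this carbon give values within the scatter of one another. The open chain 2-(methylsulfanyl)ethyl now shows that this position does not accept every group, with large steps from all three rings (an at least 2100-fold higher number from compound 3 to compound 4 (3.32 log units; beyond the scatter)), (an at least 1200-fold higher number from compound 2 to compound 4 (3.09 log units; beyond the scatter)) and (an at least 2400-fold higher number from compound 1 to compound 4 (3.38 log units; beyond the scatter)).

The compounds shown leave open whether the loss follows from the missing ring or from the sulfur in the chain. A cyclohexyl group or a pentyl chain would help separate the two.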